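Phenyl Added at Two Places on a Prenylated Purinium Core

A few compounds are considered here, and "the series" means these few. Any claim that something is new, unique, unknown or untested is made for them only; others in the source may bear on it.

Measured compounds:
compound 1 `CO/N=c1\[nH]cnc2c1[n+](C/C=C(\C)CC/C=C(/C)CCC=C(C)C)cn2C`, 1400 nM;
compound 2 `CC(C)=CCC/C(C)=C\CC/C(C)=C/C[n+]1cn(C)c2nc[nH]/c(=N\OCc3ccccc3)c21`, 7550 nM;
compound 3 `CO/N=c1\[nH]cnc2c1[n+](C/C=C(\C)CC/C=C(\C)CC/C=C(\C)CCC=C(C)C)cn2Cc1ccccc1`, 1070 nM.

In a functional assay on U-937/GTB cells (Homo sapiens) for cytotoxicity (on this read-out higher numbers stand for weaker inhibition and lower numbers for stronger inhibition), compound 1 gives 1400 nM and compound 3 gives 1070 nM; these two lie within the scatter of each other. The difference between the core of compound 1 and the core of compound 3 is not broken down here. Compound 2 gives 7550 nM; the change phenyl in place of hydrogen on a saturated chain carbon bound to an oxygen produced a 5.4-fold higher number from compound 1 to compound 2 (0.73 log units; beyond the scatter). Compound 4 `CO/N=c1\[nH]cnc2c1[n+](C/C=C(\C)CC/C=C(\C)CC/C=C(\C)CCC=C(C)C)cn2C(c1ccccc1)c1ccccc1` is not yet measured. It differs from compound 3 by phenyl in place of hydrogen on a saturated chain carbon bound to an aromatic carbon and an aromatic nitrogen: the same kind of change as that from compound 1 to compound 2, but at another place, on a saturated chain carbon bound to an aromatic carbon and an aromatic nitrogen rather than one bound to an oxygen. Resting only on the earlier step of a 5.4-fold higher number from compound 1 to compound 2 (0.73 log units; beyond the scatter), a smaller loss is expected, a 2.3-fold higher number from compound 3 to compound 4 (0.37 log units; beyond the scatter), giving an estimate for compound 4 of 2500 nM, between 900 nM and 7000 nM.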

Compound 4, half-maximal inhibitory concentration: 1970 nM
Beside the measured number, compound 4's estimate is 1.3-fold (0.10 log units) above it; low and high end bracket the measured number.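

In this assay, phenyl in place of hydrogen on a saturated chain carbon bound to an aromatic carbon and an aromatic nitrogen gave a 1.8-fold higher number from compound 3 to compound 4 (0.27 log units; within the scatter). The size of the step therefore did not carry over from the earlier pair to this one: the same change on two cores in this assay, a 5.4-fold higher number (0.73 log units; beyond the scatter) from compound 1 to compound 2 and a 1.8-fold higher number (0.27 log units; within the scatter) from compound 3 to compound 4, 2.9-fold (0.47 log units) apart, beyond the scatter of two such steps. This does not show what sets the size of the step, as the place of the phenyl and the core differ together, and one pair on each side cannot separate them.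

The compounds shown leave open how the change would read at each of the two places on the other core. Also open, on these data alone, is what an amine or a carboxylic acid in place of the phenyl would give.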